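The compounds below may be only part of what the source reports. "The series", "measured", "known", "first", "only" and "open" are said of these compounds alone.

Compound 3 `COc1ccc(-c2cc(=O)c3c(OC)cc(OC)cc3n2S(=O)(=O)c2ccc(Br)cc2)cc1` is known in a functional assay on KOPN-8 cells (Homo sapiens) for antiproliferative activity, with a stated time of 72 h (a lower number here means that less compound is needed, a higher number that more compound is needed for the effect), only as a limit. In this assay compound 3 gives > 86200 nM, a limit of the assay and not a number, and so it stands at the limit of > 86200 nM in this assay, at which 1 of the 3 values shown sits. Its two neighbours are limits as well. Compound 1 `COc1ccc(-c2cc(=O)c3c(OC)cc(OC)cc3n2S(=O)(=O)c2cccc([N+](=O)[O-])c2)cc1` gives in this assay > 39600 nM, which is a limit. Compound 2 `COc1ccc(-c2cc(=O)c3c(OC)cc(OC)cc3n2S(=O)(=O)c2ccc(F)cc2)cc1` gives in this assay > 65500 nM, again a limit. Compound 4 `COc1ccc(-c2cc(=O)c3c(OC)cc(OC)cc3n2S(=O)(=O)c2ccc(C)cc2)cc1` has not yet been measured; it differs from compound 3 by methyl in place of bromo on an aromatic carbon. The measured steps that bear on this change are those on the same sulfonyl phenyl ring: a step that the two limits leave unreadable from compound 2 to compound 3, a step that the two limits leave unreadable from compound 1 to compound 3 and a step that the two limits leave unreadable from compound 1 to compound 2. None of them has a readable size, as both ends of every step are limits. Among the measured compounds shown here, there is thus no measured step from which a direction or a size can be taken for the change from compound 3 to compound 4. Compound 4 is expected to sit near the limits of its three neighbours, and the step of an at least 1.0-fold lower number from compound 3 to compound 4 (0.03 log units; that floor lies within the scatter) is estimated as no readable change. The estimate for compound 4 in this assay is 80000 nM, with a range from 20000 nM to 300000 nM, most likely reported once more as a limit.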

Compound 4, half-maximal effective concentration: > 44800 nM
Compound 4 ended at the assay's limit (the forecaster's own chance of this, stated with the estimate: 85%); the middle value does not contradict the limit.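

In this assay, among the compounds shown here, compound 4 is known only as a limit, as are compound 1, compound 2 and compound 3, so no step from any of these three to compound 4 can be read. The compounds shown leave open whether a change on the sulfonyl phenyl ring shifts the result in this assay at all, and in which direction or by how much.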